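Catechol Diol Swapped for Dimethoxy Ether on Longer Chain

The source may report more compounds than this note shows. Statements on the series, on what has been measured and on what is new or still open speak of the compounds shown alone.

compound 1 `O=C(/C=C/c1ccc(O)c(O)c1)OCCCOc1cc(Cl)ccc1Oc1ccc(Cl)cc1Cl`: > 392000 nM (a limit of the assay, not a number)
compound 2 `O=C(/C=C/c1ccc(O)c(O)c1)OCCCCCCCOc1cc(Cl)ccc1Oc1ccc(Cl)cc1Cl`: 20000 nM

Both compounds were tested in an ADME assay on U-937 cells (Homo sapiens) for cytotoxicity, read by MTT assay, with a stated time of 72 h; a higher number here means that more compound is tolerated, a lower number that less compound is tolerated. Compound 1 sits at the limit of > 392000 nM in this assay, at which 1 of the 2 values shown sits, so no number is known for it. Among the measured compounds shown here, compound 2 gives 20000 nM in this assay, the only number among the two values shown. Compound 3 `COc1ccc(/C=C/C(=O)OCCCCCCCOc2cc(Cl)ccc2Oc2ccc(Cl)cc2Cl)cc1OC` has not yet been measured. It differs from compound 2 in one place: 3,4-dimethoxyphenyl in place of 3,4-dihydroxyphenyl on a double-bonded chain carbon bound to a double-bonded chain carbon. For the measured compounds named here, no measured pair of compounds that differ in a single place is available to size this kind of change, so the expectation rests on compound 2 alone. In this assay the step is expected to be no change at the digits printed from compound 2 to compound 3 (within the scatter), within the usual scatter and in no clear direction. Compound 3 is therefore expected to give about 20000 nM, between 6000 nM and 70000 nM.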

Compound 3, concentration lethal to 50% of the cells: 337000 nM
Beside the measured number, compound 3's estimate is 17-fold (1.23 log units) below it; the measured number lies above the stated range.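

In this assay, 3,4-dimethoxyphenyl in place of 3,4-dihydroxyphenyl gives a 17-fold higher number from compound 2 to compound 3 (1.23 log units; beyond the scatter), so far more compound is tolerated after this one change. Among the compounds shown here, this is the first pair in the set that differs in a single place, and it shows that the group on this double-bonded chain carbon strongly shifts the read-out. The swap takes the hydrogen-bond donors from 2 to 0 and keeps 2 acceptors, but one pair cannot show whether the lost donors or the added carbons drive the step.

Still open, as far as these compounds go, is whether a phenyl ring carrying one hydroxyl and one methoxy, or a plain phenyl, would give a step of similar size, and whether the same swap behaves alike on a shorter chain. Compound 1 carries a limit, not a number: the limit of > 392000 nM in this assay, at which 1 of the 3 values shown sits.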